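The source may report more compounds than this note shows. Statements on the series, on what has been measured and on what is new or still open speak of the compounds shown alone.

Series notes. In a functional assay on thoracic aorta (Rattus norvegicus, strain Wistar), with a stated time of 15 min (a lower number here means that less compound is needed, a higher number that more compound is needed for the effect), compound 1 `CCOc1ccc(Br)cc1C(C)NC(=O)N(C)S(=O)(=O)c1ccc(Cl)cc1` gives 55700 nM. Among the compounds with values here, the only other compound with a number is compound 2 `CC(C)Oc1ccc(Br)cc1C(C)NC(=O)N(C)S(=O)(=O)c1ccc(Cl)cc1`, which in this assay gives 43200 nM. Methyl in place of hydrogen on a saturated chain carbon bound to an oxygen on an aromatic ring and a saturated chain carbon gives a 1.3-fold lower number from compound 1 to compound 2 (0.11 log units; within the scatter), so compound 1 and compound 2 cannot be told apart on these numbers. Compound 3 `COc1ccc(Cl)cc1C(C)NC(=O)NS(=O)(=O)c1ccccc1` gives no number in this assay, only a limit, > 300000 nM. That value is the limit of > 300000 nM in this assay, at which 1 of the 3 values shown sits.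

Compound 4 `CCOc1ccc(F)cc1C(C)NC(=O)N(C)S(=O)(=O)c1ccc(Cl)cc1` is to be measured in this assay. Relative to compound 1 the change is fluoro in place of bromo on an aromatic carbon. Within the data shown here, no measured step touches this part of the core: the single step on record alters the ether and leaves the halogen as it is, so it gives no direct reading of swapping one halogen for another. With nothing to lean on, the expected step is a 1.4-fold higher number from compound 1 to compound 4 (0.16 log units; within the scatter), within the scatter or modestly toward a higher number. The estimate for compound 4 in this assay is 80000 nM, with a range of 30000 nM to 250000 nM.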

Compound 4, half-maximal effective concentration: 24500 nM
The estimate for compound 4 lay 3.3-fold (0.51 log units) above the measured number; measured number outside the range, below it.
By their numbers in this assay, from the lowest: compounds 4, 2 and 1 (each within the scatter of the next, the first and the last beyond it). At a limit, above all of these: compound 3.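

In this assay, within the data shown here, fluoro in place of bromo gives a 2.3-fold lower number from compound 1 to compound 4 (0.36 log units; beyond the scatter) on an aromatic carbon para to an ethoxy group, the first single change to go beyond the scatter. The ether change, a 1.3-fold lower number from compound 1 to compound 2 (0.11 log units; within the scatter), did not do so, which makes this halogen position the more responsive of the two places tested, though on one step each. Bromo is therefore not required at this position for a measured number in this assay, and no measured property at hand accounts for the step.

From the compounds shown here alone, with only bromo and fluoro compared here, it remains open whether other groups at this position, such as chloro, nitrile or trifluoromethyl, would follow the same direction, and whether fluoro and the ether of compound 2 would add up when combined. Compound 3 gives only a limit, > 300000 nM, and as it differs from the others in more than one place, that limit cannot be tied to any single part of the structure.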